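The source may report more compounds than this note shows. Statements on the series, on what has been measured and on what is new or still open speak of the compounds shown alone.

Two compounds carrying the shared core of compound 1 `C[C@H](NC(=O)Nc1ccccc1C(C)(C)C)c1ccccc1` have been measured in an ADME assay on the whole organism with Oryza sativa as the target, tested at 10 uM; on this read-out higher numbers stand for a weaker effect at the one concentration tested and lower numbers for a stronger effect. Compound 1 gives 100%, and compound 2 `CC(=O)c1ccccc1NC(=O)N[C@@H](C)c1ccccc1` gives 96%. Going by the values given here, the one step between them, a number 4 percentage points lower from compound 1 to compound 2 (within the scatter), shows that the two numbers do not differ beyond the scatter, so compound 2 stands alongside compound 1 rather than apart from it.

Compound 3 `C[C@H](NC(=O)Nc1ccccc1F)c1ccccc1` is yet to be measured. It differs from compound 2 in one place: fluoro in place of acetyl on an aromatic carbon. Among the compounds with values here, the only step that bears on a change at this aromatic carbon is a number 4 percentage points lower from compound 1 to compound 2 (within the scatter), which was within the scatter, and no change involving fluoro has been measured. On that footing no step beyond the scatter is expected in this assay, and the estimated step for compound 3 is a number 1 percentage points higher from compound 2 to compound 3 (within the scatter). Compound 3 is therefore expected to give about 97%, within a range from 85% to 100%.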

Compound 3, a percentage reported as activity, at one concentration (the size of the read-out at that concentration, not a potency): 65%
Compound 3: the middle estimate sits 32 percentage points above what was measured; the measured number lies below the stated range.
By their numbers in this assay, from the lowest: compound 3; then compounds 2 and 1 (each within the scatter of the next).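

In this assay this aromatic carbon proves sensitive to what it carries: fluoro in place of acetyl gives a number 31 percentage points lower from compound 2 to compound 3 (beyond the scatter) and fluoro in place of tert-butyl gives a number 35 percentage points lower from compound 1 to compound 3 (beyond the scatter) on the same read-out. Acetyl and tert-butyl had stayed within the scatter of each other, so the earlier pair gave no sign that a change here could move the number, and of the three groups on this carbon fluoro alone stands apart. No available evidence accounts for this difference.

The compounds shown leave open whether the lower number belongs to fluoro alone or would also come with chloro, a methyl group or an amine on this carbon. On these data alone, it also remains open whether fluoro has the same effect when other parts of the shared core change.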